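Swapping phenyl for tert-butyl on a pyridinone ketone

The compounds below may be only part of what the source reports. "The series", "measured", "known", "first", "only" and "open" are said of these compounds alone.

Three compounds have been measured in an assay on isolated protein for inhibition of 3',5'-cyclic-AMP phosphodiesterase 4A (Cavia porcellus), read by cAMP accumulation, tested at 100 uM; on this read-out higher numbers stand for a stronger effect at the one concentration tested and lower numbers for a weaker effect:

Compound 1 `CC(=O)c1cc(C(=O)c2ccccc2)c(=O)[nH]c1C`: 8.9%
Compound 2 `CC(=O)c1cc(S(=O)(=O)c2ccccc2)c(=O)[nH]c1C`: 8.72%
Compound 3 `O=C1CCCc2[nH]c(=O)c(S(=O)(=O)c3ccccc3)cc21`: 5.7%

All three numbers sit close together, each within the usual scatter of repeated measurements of the others, so none of them stands apart; compound 1 serves here as the point of departure, with compound 2 only a fraction of a point away and compound 3 a few points away, both gaps within the scatter. Every measured value is small, meaning weak inhibition at the single concentration tested.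

Compound 4 `CC(=O)c1cc(C(=O)C(C)(C)C)c(=O)[nH]c1C` has not yet been measured. It differs from compound 1 in one place: tert-butyl in place of phenyl on a carbonyl carbon. Among the compounds with values here, no measured pair shows what such a change does here, so the expectation rests on the fact that compounds 1, 2 and 3, with different groups at that position of the shared core, all give similarly low numbers in this assay. The step from compound 1 to compound 4 is therefore expected to be small, in either direction or none beyond the scatter, and is estimated as a number 1.9 percentage points lower from compound 1 to compound 4 (within the scatter). Compound 4 is expected to give about 7%, in the range -5% to 20%.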

Compound 4, a percentage reported as inhibition, at one concentration (the size of the read-out at that concentration, not a potency): 8.23%
Compound 4: middle estimate off by 1.2 percentage points, on the low side; measured number inside the range.
By their numbers in this assay, from the lowest: compounds 3, 4, 2 and 1 (each within the scatter of the next).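

In this assay, within the data shown here, the change from phenyl to tert-butyl on a carbonyl carbon gives a number 0.7 percentage points lower from compound 1 to compound 4 (within the scatter), the first step that can be read at this place. A six-membered aromatic ring can therefore give way to a smaller group with no ring, and the read-out stays within the scatter, so the aromatic ring shows no measurable importance here. No measurement shown gives a reason for this result.

On these data alone, since compound 1 and compound 4 both show only weak inhibition at the one concentration tested, it remains open whether any group on this carbonyl carbon can produce a clearly stronger effect. An amine, a carboxylic acid or a longer carbon chain at this place could test that question, and the outcome cannot be told from the compounds shown.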